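The compounds below may be only part of what the source reports. "The series", "measured", "known", "first", "only" and "open" are said of these compounds alone.

In a functional assay on the whole organism (strain albino) for inhibition, with Rattus norvegicus as the target, read by paw edema, with a stated time of 3 h, at a dose of 0.28 mmol/kg by the oral route (a higher number here means more inhibition at the dose given (going by the name of the read-out), a lower number less inhibition), compound 1 `CCn1c(SCC(=O)c2ccccc2)nnc1-c1cc(OC)c(OC)c(OC)c1` gives 49%, the lowest of the two numbers measured. For the measured compounds named here, compound 2 `CCn1c(SC/C(=N/O)c2ccccc2)nnc1-c1cc(OC)c(OC)c(OC)c1` gives 69% in this assay, and the one measured step is a number 20 percentage points higher from compound 1 to compound 2 (beyond the scatter), a change on the saturated chain carbon bound to sulfur. Compound 3 `COc1cc(-c2nnc(SCC(=O)c3ccccc3)n2-c2ccccc2)cc(OC)c1OC` differs from compound 1 by phenyl in place of ethyl on an aromatic nitrogen. Going by the values given here, no measured step touches that aromatic nitrogen, so the step from compound 1 to compound 2 does not bear on the change; no step beyond the scatter is expected in either direction. For compound 3 the estimated value in this assay is 49%, with a range from 30% to 70%. This estimate means an expected step of no change at the digits printed from compound 1 to compound 3 (within the scatter).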

Compound 3, a percentage reported as inhibition, in the whole organism at one dose (the size of the read-out at that dose, not a potency): 68%
Beside the measured number, compound 3's estimate is 19 percentage points below it; the range from low to high includes it.
By their numbers in this assay, from the lowest: compound 1; then compounds 3 and 2 (each within the scatter of the next).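

In this assay, phenyl in place of ethyl on the aromatic nitrogen gives a number 19 percentage points higher from compound 1 to compound 3 (beyond the scatter) and so shows that this position responds to substitution. Together with the earlier change, this makes the aromatic nitrogen a second place in the series, apart from the saturated chain carbon bound to sulfur, where one change moves the read-out beyond the scatter. No measured data here account for this step. Only ethyl and phenyl are shown on this nitrogen, leaving open how a benzyl group, a butyl chain or a methoxyphenyl group would read. Also open, as far as these compounds go, is whether phenyl on this nitrogen and the change on the chain carbon would add up in one compound.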